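This account rests on a few compounds, and the source may have more. Where it says the series, first, only, none or still open, it means among the compounds named here.

Measured compounds:
compound 1 `N[C@H]1CC[C@H](Nc2c(C(=O)NCc3ccc(F)cc3)nc(Br)c3cccnc23)CC1` — in a functional assay on HCT-116 cells (Homo sapiens) for cytotoxicity, read by MTT assay, with a stated time of 72 h (a lower number here means a stronger inhibitor, a higher number a weaker inhibitor), compound 1 gives 4000 nM.
compound 2 `NCCCCCCNc1c(C(=O)NCc2ccc(F)cc2)nc(Br)c2cccnc12` — in this assay compound 2 gives > 10000 nM, a limit of the assay.
compound 3 `CNc1c(C(=O)NCc2ccc(F)cc2)nc(Br)c2cccnc12` — in this assay compound 3 gives > 20000 nM, a limit of the assay.

Compound 3 stands at the weak end of what is shown: its value is only a limit, (the limit of > 20000 nM in this assay, at which 1 of the 3 values shown sits), and compound 2 likewise sits at a limit, (the limit of > 10000 nM in this assay, at which 1 of the 3 values shown sits). Among the measured compounds shown here, the one readable step into compound 3 is an at least 5.0-fold higher number from compound 1 to compound 3 (0.69 log units; beyond the scatter); the other, a step that the two limits leave unreadable from compound 2 to compound 3.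

Compound 4 `O=C(NCc1ccc(F)cc1)c1nc(Br)c2cccnc2c1NCCO` differs from compound 3 by hydroxymethyl in place of hydrogen on a saturated chain carbon bound to a nitrogen on an aromatic ring. For the measured compounds named here, no measured step adds a hydroxymethyl here, so the change has no direct precedent; the nearest comparisons, compounds 1 and 2 against compound 3, show a large group on that nitrogen giving at best a modest gain. A small addition is expected to change little: a number no higher from compound 3 to compound 4 (the limit leaves the size open). Compound 4 is therefore estimated at 20000 nM, between 6000 nM and 60000 nM, most likely again reported as a limit.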

Compound 4, half-maximal inhibitory concentration: > 20000 nM
Compound 4 gave a limit, no number; the forecaster's own chance of this, stated with the estimate: 70%; the middle value lies on the limit itself.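

In this assay compound 4 gives > 20000 nM, a limit of the assay, and it shares that limit with compound 3: the limit of > 20000 nM in this assay, at which 2 of the 4 values shown sit. On this nitrogen, 2-hydroxyethyl gives no number, and it stands apart from 4-aminocyclohexyl, with an at least 5.0-fold higher number from compound 1 to compound 4 (0.69 log units; beyond the scatter). The steps into compound 4 from compound 2 and compound 3 cannot be read, as both ends are limits.

Still open, going by these compounds, is whether a short chain ending in an amine, such as 2-aminoethyl, would give a number in this assay. Also open, on these data alone, is whether a plain cyclohexyl, without the amine of compound 1, would do so.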